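Compound 4 and the Cytotoxicity Limit

A few compounds are considered here, and "the series" means these few. Any claim that something is new, unique, unknown or untested is made for them only; others in the source may bear on it.

In an ADME assay on MT4 cells (Homo sapiens) for cytotoxicity, read by XTT assay, with a stated time of 5 days (on this read-out lower numbers stand for higher toxicity in this test and higher numbers for lower toxicity in this test), the compounds read as follows:
Compound 1 `COC(=O)N[C@H](C(=O)NN(CC[C@@](O)(Cc1ccccc1)C(=O)N[C@H]1c2ccccc2C[C@H]1O)Cc1ccc(-c2ccccc2)cc1)C(C)(C)C` gives > 10000 nM
Compound 2 `COC(=O)N[C@H](C(=O)NN(CC[C@@](O)(Cc1ccccc1)C(=O)N[C@H]1c2ccccc2C[C@H]1O)Cc1ccc(-c2ccncc2)cc1)C(C)(C)C` gives > 10000 nM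
Compound 3 `COC(=O)N[C@H](C(=O)NN(CC[C@@](O)(Cc1ccccc1)C(=O)N[C@H]1c2ccccc2C[C@H]1O)Cc1ccc(-c2ccc(NC(C)=O)cc2)cc1)C(C)(C)C` gives > 10000 nM

Each of these entries is a limit and not a number. Compound 3 thus stands only at a limit (the limit of > 10000 nM in this assay, at which 3 of the 3 values shown sit). Compound 4 `COC(=O)N[C@H](C(=O)NN(CC[C@@](O)(Cc1ccccc1)C(=O)N[C@H]1c2ccccc2C[C@H]1O)Cc1ccc(-c2c(C)noc2C)cc1)C(C)(C)C` carries 3,5-dimethyl-1,2-oxazol-4-yl in place of 4-acetamidophenyl on an aromatic carbon. The steps a step that the two limits leave unreadable from compound 1 to compound 2 and a step that the two limits leave unreadable from compound 1 to compound 3 and a step that the two limits leave unreadable from compound 2 to compound 3 bear on this change, and none has a readable size. No step beyond the scatter is therefore expected in this assay and no direction is favoured. The expected outcome is a step that the limit leaves unreadable from compound 3 to compound 4 at most in name only, with the reading staying close to the same limit. The estimate for compound 4 is 12000 nM (range 6000 nM to 25000 nM).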

Compound 4, half-maximal cytotoxic concentration: > 10000 nM
Compound 4 was reported as a limit; the forecaster's own chance of this, stated with the estimate: 85%; the middle value does not contradict the limit.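

Within the data shown here, compound 4 is reported only as a limit, as are compound 1, compound 2 and compound 3, so no step among them can be read. The compounds shown leave open at what concentration any of them becomes toxic, and whether changing the group on the aromatic carbon alters that: the limit of > 10000 nM in this assay, at which 4 of the 4 values shown sit.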